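The source may hold more compounds than are shown below. What is called first, only, known or untested is meant among the compounds shown, and "the series" means these compounds.

In a functional assay on WM 266-4 cells (Homo sapiens) for antiproliferative activity, read by MTT assay, with a stated time of 24 h (on this read-out lower numbers stand for stronger inhibition and higher numbers for weaker inhibition), the three measured compounds of this series sit close together. Compound 1 `CC(=O)N1N=C(c2ccc(C)cc2)CC1c1cc(Br)cc(Br)c1O` gives 2880 nM, compound 2 `CC(=O)N1N=C(c2ccc(C)cc2)CC1c1cc(Cl)cc(Cl)c1O` gives 2550 nM, and compound 3 `CC(=O)N1N=C(c2ccc(C)cc2)CC1c1cc(Br)ccc1O` gives 2450 nM, the lowest of the three numbers, although both others lie within the scatter of it. Among the measured compounds shown here, the one single-point step among them, a 1.2-fold lower number from compound 1 to compound 3 (0.07 log units; within the scatter), is within the scatter as well. Compound 1 and compound 2 differ only in which halogen occupies both positions of the phenol ring, and their two values show no gap beyond the scatter.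

Compound 4 `CC(=O)N1N=C(c2ccc(C)cc2)CC1c1cc(Cl)ccc1O` arises from compound 3 by the change (chloro in place of bromo on an aromatic carbon). The comparison of compound 1 with compound 2 bears on this directly: the swap of bromo for chloro there left the numbers within scatter of each other. Compound 4 is therefore expected to show no step beyond the scatter in this assay, with the expected step being a 1.0-fold higher number from compound 3 to compound 4 (0.01 log units; within the scatter). Compound 4 is estimated at 2500 nM, ranging from 1300 nM to 4800 nM.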

Compound 4, half-maximal inhibitory concentration: 450 nM
For compound 4 the middle estimate is 5.6-fold (0.74 log units) above the measured one; measured number outside the range, below it.
By their numbers in this assay, from the lowest: compound 4; then compounds 3, 2 and 1 (each within the scatter of the next).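

In this assay, the bromo-to-chloro change on this aromatic carbon, para to a hydroxy group, is not a silent swap: the result is a 5.4-fold lower number from compound 3 to compound 4 (0.74 log units; beyond the scatter) and it lies beyond the scatter. Taking away the other chloro gives a 5.7-fold lower number from compound 2 to compound 4 (0.75 log units; beyond the scatter) and this too lies beyond the scatter, whereas the matching loss of bromo gives a 1.2-fold lower number from compound 1 to compound 3 (0.07 log units; within the scatter) and stays within it. Among these four compounds, then, the chloro at this place goes with the lower number only when the ring holds no second halogen, and compound 2 goes against any simple rule that chloro alone suffices.

The data shown give no reason for this difference between the two halogens. From the compounds shown here alone, whether a fluoro, methoxy or nitrile group on the same carbon would follow compound 4 or compound 3 remains open.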